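The compounds below may be only part of what the source reports. "The series", "measured", "known", "first", "only" and "open" are said of these compounds alone.

Compound 1 `COc1cc(C(=O)c2cn(-c3cccc(C)c3)cc2-c2ccsc2)cc(OC)c1OC`: 65 nM
Compound 2 `COc1cc(C(=O)c2cn(-c3cccc(C)c3)cc2-c2ccoc2)cc(OC)c1OC`: 21 nM
Compound 3 `COc1cc(C(=O)c2cn(-c3cccc(C)c3)cc2-c2ccccn2)cc(OC)c1OC`: 140 nM

In a functional assay on MCF7 cells (Homo sapiens) for inhibition, with a stated time of 96 h (a lower number here means a stronger inhibitor, a higher number a weaker inhibitor), compound 3 gives 140 nM, the highest number of the three, which makes it the weakest inhibitor measured so far. Compound 4 `COc1cc(C(=O)c2cn(-c3cccc(C)c3)cc2-c2cccnc2)cc(OC)c1OC` has not yet been measured. It has the same atoms as compound 3, joined differently: pyridin-3-yl in place of pyridin-2-yl on an aromatic carbon. The change lies on an aromatic carbon of a five-membered aromatic ring with 1 nitrogen.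

Three measured steps involve this same place. The swap to pyridin-2-yl gave a 2.2-fold higher number from compound 1 to compound 3 (0.33 log units; beyond the scatter) and also a 6.7-fold higher number from compound 2 to compound 3 (0.82 log units; beyond the scatter). Even the exchange between the two five-membered groups gave a 3.1-fold lower number from compound 1 to compound 2 (0.49 log units; beyond the scatter), so the number does respond to what sits here. Among the measured compounds shown here, no measured pair shows what happens when only the ring nitrogen moves, so the direction is uncertain. Compound 3 already stands at the top of the range, and pyridin-3-yl shares its "3-yl" ending with the groups in compound 1 and compound 2. A modest move to a lower number in this assay therefore seems more likely than a rise.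

The expected change is a 2.3-fold lower number from compound 3 to compound 4 (0.37 log units; beyond the scatter). For compound 4 the estimated value is 60 nM, with an expected range from 20 nM to 170 nM.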

Compound 4, half-maximal inhibitory concentration: 52 nM
Compound 4: middle estimate off by 1.2-fold (0.06 log units), on the high side; the measured number falls inside the stated range.
By their numbers in this assay, from the lowest: compound 2; then compounds 4 and 1 (each within the scatter of the next); then compound 3.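

Moving only the ring nitrogen, with the same atoms in the same kind of six-membered ring, gives a 2.7-fold lower number from compound 3 to compound 4 (0.43 log units; beyond the scatter) in this assay, so the number at this position depends on where that nitrogen sits and not just on its presence. A six-membered group is also no handicap here in itself: the pyridin-3-yl group of compound 4 cannot be told apart from the thiophen-3-yl group, with a 1.3-fold lower number from compound 1 to compound 4 (0.10 log units; within the scatter), while the furan-3-yl group keeps its lead, with a 2.5-fold higher number from compound 2 to compound 4 (0.39 log units; beyond the scatter). Nothing measured explains why the place of the nitrogen matters.

Still open, as far as these compounds go, is how pyridin-4-yl, the remaining way of attaching this ring, would compare, and whether a group that is not an aromatic ring, such as a morpholine or a simple amine, would be tolerated at this position. Every compound here also carries the same 3-methylphenyl group, so it remains unknown whether the order among these groups would hold if that group were replaced by another, such as a plain phenyl.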